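The source may report more compounds than this note shows. Statements on the series, on what has been measured and on what is new or still open speak of the compounds shown alone.

Working notes. In an assay on isolated protein for inhibition of Nitric oxide synthase, inducible (Homo sapiens), read by scintillation counting, with a stated time of 30 min, tested at 50 uM (on this read-out higher numbers stand for more inhibition at the one concentration tested (going by the name of the read-out) and lower numbers for less inhibition), compound 3 `CCCCC(=O)N1N=C(c2cc(Cl)ccc2N)SC1(C)C` gives 12.6%, the lowest of the three numbers; compound 1 `COc1ccc(N)c(C2=NN(C(=O)C3CCCC3)C(C)(C)S2)c1` gives 65% and compound 2 `CC(=O)N1N=C(c2cc(Cl)ccc2N)SC1(C)C` gives 72.8%. Compound 4 `CC1(C)SC(c2cc(Cl)ccc2N)=NN1C(=O)C1CCCC1` differs from compound 3 by cyclopentyl in place of butyl on a carbonyl carbon on a carbonyl carbon. Among the compounds with values here, the only step that bears on this position is a number 60.2 percentage points lower from compound 2 to compound 3 (beyond the scatter), a large fall from lengthening the chain on the carbonyl. Compound 4 carries the same cyclopentylcarbonyl group as compound 1, which in turn bears a different substituent on the aromatic ring. In this assay compound 1 gives 65%, well above compound 3. The step to compound 4 is therefore expected to be a rise, a number 32.4 percentage points higher from compound 3 to compound 4 (beyond the scatter), with wide uncertainty. Compound 4 is estimated at 45%, within 15% to 75%.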

Compound 4, a percentage reported as inhibition, at one concentration (the size of the read-out at that concentration, not a potency): 21.3%
Beside the measured number, compound 4's estimate is 23.7 percentage points above it; the range from low to high includes it.
By their numbers in this assay, from the lowest: compounds 3 and 4 (each within the scatter of the next); then compounds 1 and 2 (each within the scatter of the next).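

In this assay a ring on the carbonyl brings no recovery: with a number 8.7 percentage points higher from compound 3 to compound 4 (within the scatter) cyclopentyl and butyl cannot be told apart, and with a number 51.5 percentage points lower from compound 2 to compound 4 (beyond the scatter) the fall from methyl appears for a ring as it did for a chain. With a number 43.7 percentage points lower from compound 1 to compound 4 (beyond the scatter) for chloro in place of methoxy, the cyclopentylcarbonyl group alone does not set the number; the aromatic substituent counts as well. Nothing at hand gives a reason for these steps. Still open, from the compounds shown here alone, is whether the fall already sets in with a smaller group on the carbonyl, such as ethyl or cyclopropyl. Also open, going by these compounds, is whether an amine on that chain would change it.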